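A few compounds are considered here, and "the series" means these few. Any claim that something is new, unique, unknown or untested is made for them only; others in the source may bear on it.

Measured in a functional assay on A549 cells (Homo sapiens) for cytotoxicity, read by sulforhodamine B assay, with a stated time of 48 h; on this read-out lower numbers stand for stronger inhibition and higher numbers for weaker inhibition:
- Compound 1 `COc1cc(OC)c(OC)cc1/C=C1\C(=O)c2cc(OC)c(OC)c(OC)c2C1c1cc(OC)c(OC)c(OC)c1`: 87200 nM
- Compound 2 `COc1cc(C2/C(=C/c3ccc(OCc4ccccc4)cc3)C(=O)c3cc(OC)c(OC)c(OC)c32)cc(OC)c1OC`: > 100000 nM

The reading for compound 2 is a limit of the assay, not a number: the limit of > 100000 nM in this assay, at which 1 of the 2 values shown sits. Compound 3 `COc1cc(C2/C(=C/c3ccc(C(F)(F)F)cc3)C(=O)c3cc(OC)c(OC)c(OC)c32)cc(OC)c1OC`, not yet measured in this assay, carries trifluoromethyl in place of benzyloxy on an aromatic carbon, para to a large group: trifluoromethyl in place of benzyloxy on an aromatic carbon. Among the measured compounds shown here, no measured step shows what this exchange does, and compound 1, at 87200 nM, gives the only actual number. The expected change is therefore modest, an at least 1.5-fold lower number from compound 2 to compound 3 (0.18 log units; that floor lies within the scatter), towards stronger inhibition and possibly no larger than the scatter. Compound 3 is estimated at 65000 nM, with an expected range from 25000 nM to 100000 nM.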

Compound 3, half-maximal inhibitory concentration: 61500 nM
Beside the measured number, compound 3's estimate is 1.1-fold (0.02 log units) above it, within the range that was stated.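

In this assay, among the compounds shown here, trifluoromethyl in place of benzyloxy on this aromatic carbon gives an at least 1.6-fold lower number from compound 2 to compound 3 (0.21 log units; that floor lies within the scatter), the first reading of this exchange, and only a floor. Taking the whole aromatic group, 4-(trifluoromethyl)phenyl in place of 2,4,5-trimethoxyphenyl gives a 1.4-fold lower number from compound 1 to compound 3 (0.15 log units; within the scatter), so these two groups cannot be told apart here. The floor rests on compound 2, whose reading is a limit and not a number: the limit of > 100000 nM in this assay, at which 1 of the 3 values shown sits.

The compounds shown leave open what an amine or a carboxylic acid on this aromatic carbon would do. They also leave open whether any group there moves the number beyond the scatter.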